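The source may report more compounds than this note shows. Statements on the series, on what has been measured and on what is new or still open speak of the compounds shown alone.

Measured in a functional assay on A549 cells (Homo sapiens), read by sulforhodamine B assay, with a stated time of 5 days; a higher number here means a weaker inhibitor of growth, a lower number a stronger inhibitor of growth:
- compound 1 `OC[C@H]1O[C@@H](n2cc(Cl)c3c(-c4ccccc4)ncnc32)[C@H](O)[C@@H]1O`: 2500 nM
- compound 2 `OC[C@H]1O[C@@H](n2cc(Cl)c3c(-c4ccoc4)ncnc32)[C@H](O)[C@@H]1O`: 1100 nM

Compound 2 holds the lower of the two numbers, and the gap to compound 1 lies beyond the scatter. Compound 3 `OC[C@H]1O[C@@H](n2cc(Cl)c3c(-c4ccsc4)ncnc32)[C@H](O)[C@@H]1O` differs from compound 2 by one change: thiophen-3-yl in place of furan-3-yl on an aromatic carbon. In words, this is thiophen-3-yl in place of furan-3-yl on an aromatic carbon. For the measured compounds named here, no compound with thiophen-3-yl has been measured, so one step at this carbon is the only guide. That step, phenyl to furan-3-yl, was modest: a 2.3-fold lower number from compound 1 to compound 2 (0.36 log units; beyond the scatter). The present change keeps a five-membered aromatic ring with one hetero atom, so a smaller move is expected in this assay, with no clear direction and nothing beyond the scatter. The expected step is a 1.1-fold lower number from compound 2 to compound 3 (0.04 log units; within the scatter). Compound 3 is estimated at 1000 nM, with an expected range of 350 nM to 2800 nM.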

Compound 3, concentration for 50% growth inhibition: 380 nM
Compound 3: the middle estimate sits 2.6-fold (0.42 log units) above what was measured, and the stated range covers the measured number.
By their numbers in this assay, from the lowest: compound 3; then compound 2; then compound 1.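

In this assay, the swap of one five-membered aromatic ring for another at this carbon is not silent: it gives a 2.9-fold lower number from compound 2 to compound 3 (0.46 log units; beyond the scatter) even though furan-3-yl and thiophen-3-yl match in heavy atoms and in hydrogen-bond counts. Across the three groups, the widest gap is a 6.6-fold lower number from compound 1 to compound 3 (0.82 log units; beyond the scatter), so this position separates phenyl, furan-3-yl and thiophen-3-yl, with thiophen-3-yl holding the lowest number. Nothing available explains the difference between the oxygen and sulfur rings.

From the compounds shown here alone, it remains open whether this order extends to thiophen-2-yl or furan-2-yl, or to a thiophen-3-yl ring bearing an amine or a carboxylic acid. Going by these compounds, whether this carbon requires an aromatic ring at all also remains open, since a morpholine or a longer alkyl chain would test that directly.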